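The source may hold more compounds than are shown below. What is called first, only, known or untested is meant among the compounds shown, and "the series" means these compounds.

Going by the values given here, in an ADME assay (liver) for pharmacokinetics, with Liver microsome (Rattus norvegicus) as the target, read by LC-MS, using microsomes, tested at 2 uM (a lower number here means slower removal, a higher number faster removal of the compound), compound 1 `Cc1cc(COc2ncc(C(=O)N[C@@H]3CCCC[C@H]3O)cc2-c2ccc(Cl)cc2)on1` gives 0.151 mL/min/kg while compound 2 `O=C(N[C@@H]1CCCC[C@H]1O)c1cnc(OCc2ncccn2)c(-c2ccc(Cl)cc2)c1` gives 0.012 mL/min/kg as the lower of the two numbers measured so far. The two differ in one place only, the group on a saturated chain carbon bound to an oxygen on an aromatic ring, and the swap of 3-methyl-1,2-oxazol-5-yl for pyrimidin-2-yl there makes a large step: a 13-fold lower number from compound 1 to compound 2 (1.10 log units; beyond the scatter) and so beyond the scatter. Compound 3 `O=C(N[C@@H]1CCCC[C@H]1O)c1cnc(OCc2ccncc2)c(-c2ccc(Cl)cc2)c1` alters that same place again, with pyridin-4-yl in place of pyrimidin-2-yl (pyridin-4-yl in place of pyrimidin-2-yl on a saturated chain carbon bound to an oxygen on an aromatic ring). The step from compound 1 is the only measured one that bears on this change. It shows that the group at this place can move the number a long way, but it involves a different pair of groups. Compound 2 sits at 0.012 mL/min/kg at the low end of just two numbers, so a rise is expected in this assay rather than a further fall. The expected move is a 4.2-fold higher number from compound 2 to compound 3 (0.62 log units; beyond the scatter) and is only an estimate. Compound 3 is estimated at 0.05 mL/min/kg with an expected range from 0.012 mL/min/kg to 0.2 mL/min/kg on this scale.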

Compound 3, clearance: 0.118 mL/min/kg
Compound 3: middle estimate off by 2.4-fold (0.37 log units), on the low side, and the stated range covers the measured number.
By their numbers in this assay, from the lowest: compound 2; then compounds 3 and 1 (each within the scatter of the next).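

In this assay, the step of a 9.8-fold higher number from compound 2 to compound 3 (0.99 log units; beyond the scatter) shows that the low number of compound 2 does not come with every six-membered aromatic ring at this place, even though pyrimidin-2-yl and pyridin-4-yl have the same heavy-atom count and differ in having two hetero atoms or one. The step of a 1.3-fold lower number from compound 1 to compound 3 (0.11 log units; within the scatter) lies within the scatter, so pyridin-4-yl and 3-methyl-1,2-oxazol-5-yl cannot be told apart here, and among these three groups only pyrimidin-2-yl stands apart from the others. No measurement offered here gives a reason for this gap.

Still open, going by these compounds, is whether the gap follows the second ring nitrogen or the way the ring is joined to the chain, and a pyridin-2-yl group at this place would help separate those two readings. Also open, on these data alone, is where a plain phenyl group, with no ring nitrogen at all, would fall on this scale, and whether the same swap gives a step of similar size on a different core.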